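Adding a Methyl to Compound 2

A few compounds are considered here, and "the series" means these few. Any claim that something is new, unique, unknown or untested is made for them only; others in the source may bear on it.

compound 1 `Cc1ccccc1OCC(=O)Nc1ccccc1C(N)=O`: 19.7%
compound 2 `Cc1ccc(NC(=O)COc2ccccc2)c(C(N)=O)c1`: 72%

In a functional assay on K562 cells (Homo sapiens) for inhibition, read by trypan blue exclusion, with a stated time of 24 h, tested at 10 uM (on this read-out higher numbers stand for more inhibition of growth at the one concentration tested and lower numbers for less inhibition of growth), compound 2 gives 72% and stands highest of the two numbers, beyond the scatter above compound 1. Compound 3 `Cc1ccc(NC(=O)COc2ccccc2C)c(C(N)=O)c1` is compound 2 with one change methyl in place of hydrogen on an aromatic carbon, turning phenyl into 2-methylphenyl. Among the measured compounds shown here, no measured step shows this change alone. Compound 1 also carries 2-methylphenyl and in this assay gives only 19.7% so some loss seems likely. The expected change is a fall, estimated as a number 22 percentage points lower from compound 2 to compound 3 (beyond the scatter) and beyond the scatter. Compound 3 is expected at 50% with a range from 20% to 80%.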

Compound 3, percent growth inhibition at one concentration: 45.6%
Compound 3: middle estimate off by 4.4 percentage points, on the high side; low and high end bracket the measured number.
By their numbers in this assay, from the lowest: compound 1; then compound 3; then compound 2.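

The phenyl to 2-methylphenyl change now has a step of its own: in this assay it gives a number 26.4 percentage points lower from compound 2 to compound 3 (beyond the scatter) and so lowers growth inhibition at this place. Compound 3 still carries a second methyl in place of hydrogen on an aromatic carbon, and that change gives a number 25.9 percentage points higher from compound 1 to compound 3 (beyond the scatter) in the opposite direction. Nothing measured here explains why these two methyl groups differ.

As far as these compounds go, what a chlorine atom, a methoxy group or an amine would do in place of this methyl stays open.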